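The source may hold more compounds than are shown below. What is called first, only, known or untested is meant among the compounds shown, and "the series" means these compounds.

Working notes on the series. Compound 1 `CCC(=O)Nc1ccc(S(=O)(=O)N(CC(N)=O)c2ccc(N(CC(N)=O)S(=O)(=O)c3ccc(OC)cc3)c3ccccc23)cc1` is tested in a functional assay on cells (Peritoneal macrophage, Mus musculus) for cytotoxicity, with a stated time of 24 h; a lower number here means that less compound is tolerated, a higher number that more compound is tolerated. In this assay compound 1 gives no number but only a limit, > 50000 nM. Compound 2 `COc1ccc(S(=O)(=O)N(CC(N)=O)c2ccc(N(CC(N)=O)S(=O)(=O)c3ccc(NC(=O)CN4CCC(C)CC4)cc3)c3ccccc23)cc1` likewise gives only a limit in this assay, > 50000 nM. Compound 3 `COc1ccc(S(=O)(=O)N(CC(N)=O)c2ccc(N(CC(N)=O)S(=O)(=O)c3ccc(NC(=O)CCN4CCCCC4)cc3)c3ccccc23)cc1` gives only a limit in this assay, > 100000 nM. The step that the two limits leave unreadable from compound 1 to compound 2 cannot be read, and the same holds for a step that the two limits leave unreadable from compound 1 to compound 3 and for a step that the two limits leave unreadable from compound 2 to compound 3. Compound 3 sits at the limit of > 100000 nM in this assay, at which 1 of the 3 values shown sits. The other two compounds sit at the limit of > 50000 nM in this assay, at which 2 of the 3 values shown sit. Compound 4 `COc1ccc(S(=O)(=O)N(CC(N)=O)c2ccc(N(CC(N)=O)S(=O)(=O)c3ccc(NC(=O)CCN4CCC(C)CC4)cc3)c3ccccc23)cc1` differs from compound 3 by methyl in place of hydrogen on a saturated ring carbon. Among the measured compounds shown here, none of the measured steps yields a readable size, so no step beyond the scatter is expected in this assay in either direction. The step that the limit leaves unreadable from compound 3 to compound 4 is therefore estimated to be nil. Compound 4 is expected to give 150000 nM in this assay, within a range of 50000 nM to 500000 nM, and most probably to be reported again only as a limit.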

Compound 4, half-maximal cytotoxic concentration: > 100000 nM
Compound 4: only a limit was reported (the forecaster's own chance of this, stated with the estimate: 90%); the middle value lies beyond the limit too.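

Compound 4, like compound 1, compound 2 and compound 3, is reported in this assay only as a limit, so none of the steps to compound 4 can be read. The compounds shown leave open at what concentration any of them becomes cytotoxic, and whether methyl in place of hydrogen on the saturated ring carbon alters that concentration.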